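A few compounds are considered here, and "the series" means these few. Any claim that something is new, unique, unknown or untested is made for them only; others in the source may bear on it.

Measured so far:
- compound 1 `CN(C)CC(=O)NCC(=O)N(C)c1ccc(Cl)cc1C(=O)c1ccccc1Cl`: in a functional assay on the whole organism with Mus musculus as the target, in the rotarod test (on this read-out higher numbers stand for an effect only at larger amounts of compound and lower numbers for an effect already at smaller amounts), compound 1 gives 26 mg/kg
- compound 2 `NCC(=O)NCC(=O)Nc1ccc([N+](=O)[O-])cc1C(=O)c1ccccc1`: in this assay compound 2 gives 24.8 mg/kg

Compound 1 has the higher of the two numbers, but the gap to compound 2 lies within the scatter of repeated measurements, so the two compounds cannot be told apart on this read-out. For the measured compounds named here, no step between the measured compounds differs in only one place, so nothing is known here about how a single change shifts the number.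

Compound 3 `CN(C(=O)CNC(=O)CN1CCN(c2ccccc2)CC1)c1ccc(Cl)cc1C(=O)c1ccccc1Cl` is not yet measured. It differs from compound 1 in one place: 4-phenylpiperazin-1-yl in place of dimethylamino on a saturated chain carbon bound to a carbonyl carbon. The change sits on a saturated chain carbon bound to a carbonyl carbon, away from the shared core. Going by the values given here, no measured pair speaks to this change, so no direction can be drawn from the data; the expected step from compound 1 to compound 3 is a 1.2-fold higher number from compound 1 to compound 3 (0.06 log units; within the scatter), not beyond the scatter. Compound 3 is thus estimated at 30 mg/kg, with a range from 10 mg/kg to 90 mg/kg.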

Compound 3, dose for half-maximal effect: > 100 mg/kg
Compound 3 gave a limit, no number; the forecaster's own chance of this, stated with the estimate: 15%; at least 3.3-fold (0.52 log units) between middle value and limit.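

Moving from dimethylamino to 4-phenylpiperazin-1-yl on a saturated chain carbon bound to a carbonyl carbon gives the first single-place step in the series, and this position proves sensitive to the change: an at least 3.8-fold higher number from compound 1 to compound 3 (0.58 log units; beyond the scatter). Here the group that leaves has 3 heavy atoms and no ring, while the group that enters has 12 heavy atoms and two six-membered rings. In this assay, the entry for compound 3 is a limit and not a number, so the true size of the step stays unresolved: the limit of > 100 mg/kg in this assay, at which 1 of the 3 values shown sits.

For the compounds shown here, the single step does not separate the contribution of the piperazine ring from that of the phenyl ring. On these data alone, it also remains open whether morpholin-4-yl or 4-methylpiperazin-1-yl at the same place would stay close to compound 1 or move towards compound 3.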